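Removing the nitro group from a hydrazone that reads at the limit

The source may report more compounds than this note shows. Statements on the series, on what has been measured and on what is new or still open speak of the compounds shown alone.

Compound 1 `O=c1cc(/C=N\c2ccc(O)cc2)c2ccc(OCc3ccccc3)cc2o1` gives 525000 nM in a functional assay, read by spectrophotometry, with a stated time of 5 min; on this read-out lower numbers stand for stronger inhibition and higher numbers for weaker inhibition.
Compound 2 `Nc1ccccc1/N=C\c1cc(=O)oc2cc(OCc3ccccc3)ccc12` gives 217000 nM in this assay.
Compound 3 `O=c1cc(/C=N\Nc2ccc([N+](=O)[O-])cc2)c2ccc(OCc3ccccc3)cc2o1` gives > 2000000 nM in this assay, a limit rather than a number.

Compound 3 thus stands at the weak end of the set, where the limit of > 2000000 nM in this assay, at which 1 of the 3 values shown sits, applies. Compound 4 `O=c1cc(/C=N\Nc2ccccc2)c2ccc(OCc3ccccc3)cc2o1` differs from it by hydrogen in place of nitro on an aromatic carbon. Among the measured compounds shown here, no measured step removes a nitro group, so the only guidance is indirect: an at least 3.8-fold higher number from compound 1 to compound 3 (0.58 log units; beyond the scatter) and an at least 9.2-fold higher number from compound 2 to compound 3 (0.96 log units; beyond the scatter) show that the (4-nitrophenyl)amino variant reads at the limit, but they do not separate the nitro group from the anilino linkage. A modest drop toward a measurable number is expected, with an at least 1.3-fold lower number from compound 3 to compound 4 (0.12 log units; that floor lies within the scatter). Compound 4 is therefore estimated at 1500000 nM, somewhere between 400000 nM and 4000000 nM.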

Compound 4, half-maximal inhibitory concentration: 416000 nM
Beside the measured number, compound 4's estimate is 3.6-fold (0.56 log units) above it; the range from low to high includes it.
By their numbers in this assay, from the lowest: compounds 2, 4 and 1 (each within the scatter of the next, the first and the last beyond it). At a limit, above all of these: compound 3.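

In this assay, removing the nitro group gives an at least 4.8-fold lower number from compound 3 to compound 4 (0.68 log units; beyond the scatter), which shows that the anilino linkage alone does not hold a compound at the limit. Without the nitro group, the hydrazone reads level with the two imines, with a 1.9-fold higher number from compound 2 to compound 4 (0.28 log units; within the scatter) and a 1.3-fold lower number from compound 1 to compound 4 (0.10 log units; within the scatter). The reading for compound 3 is a limit, so the first step gives only a floor: the limit of > 2000000 nM in this assay, at which 1 of the 4 values shown sits.

As far as these compounds go, whether an amine, a methoxy group or a chlorine on that aromatic carbon would also give a measurable number remains open. So does what a nitro group would do on the imines.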